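Swapping a Methylpyridine for Chlorophenyl on a Piperidine

This account rests on a few compounds, and the source may have more. Where it says the series, first, only, none or still open, it means among the compounds named here.

Measured so far:
- compound 1, `Cc1cccc(NC(=O)CN2CCN(c3cccc4ccccc34)CC2)c1`: 4250 nM
- compound 2, `Cc1ccc(C2CCN(CC(=O)Nc3cccc(C)c3)CC2)nc1`: 394 nM

Two compounds have been run through an assay on cells for antagonist activity at D(4) dopamine receptor (Homo sapiens), read by luminescence and beta-arrestin recruitment, with a stated time of 90 min; a higher number here means a weaker inhibitor, a lower number a stronger inhibitor. Compound 1 carries a naphthyl on a piperazine and gives 4250 nM in this assay. Compound 2 carries a methylpyridine on a piperidine and gives 394 nM in this assay, the lower of the two numbers; the gap to compound 1 lies well beyond the usual scatter, so compound 2 stands as the stronger inhibitor of the pair.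

Compound 3, `Cc1cccc(NC(=O)CN2CCC(c3ccc(Cl)cc3)CC2)c1`, has not been measured yet. It keeps the whole anilide and piperidine part of compound 2 and changes only the aromatic group on the saturated ring: 4-chlorophenyl in place of 5-methylpyridin-2-yl on a saturated ring carbon. Among the measured compounds shown here, no measured pair shows this exact exchange, so the size of its effect can only be guessed.

The expectation is that compound 3 stays close to compound 2, with at most a modest shift in either direction, and the estimated step of a 1.6-fold lower number from compound 2 to compound 3 (0.20 log units; within the scatter) reflects a small gain. Compound 3 is expected to give about 250 nM in this assay, somewhere between 60 nM and 1500 nM.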

Compound 3, half-maximal inhibitory concentration: 42400 nM
Compound 3: the middle estimate sits 170-fold (2.23 log units) below what was measured; measured number outside the range, above it.
By their numbers in this assay, from the lowest: compound 2; then compound 1; then compound 3.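

In this assay, placing 4-chlorophenyl where 5-methylpyridin-2-yl stood on the saturated ring carbon gives a 110-fold higher number from compound 2 to compound 3 (2.03 log units; beyond the scatter), so this position is far from indifferent to which aromatic group it carries. The size of the step is striking for so small an exchange: both groups are a single six-membered aromatic ring with the same count of heavy atoms, and the rest of the molecule stays the same. What the two groups differ in is that the leaving group has a ring nitrogen, which counts as a hydrogen-bond acceptor, and a methyl, while the entering group has an all-carbon ring and a chlorine; no measurement offered here explains how either difference relates to the result.

The compounds shown leave open whether the ring nitrogen, the exchange of methyl for chlorine, or the two together account for the step. A 4-methylphenyl group at this place would differ from compound 2 only in the ring nitrogen, and a 5-chloropyridin-2-yl group only in the chlorine, so either one would help to separate the two changes.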